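The source may hold more compounds than are shown below. What is called first, only, known or untested is meant among the compounds shown, and "the series" means these compounds.

Three compounds share one core and differ only in the group on a carbonyl carbon: compound 1 (`CCn1c(C(=O)NCCN(C)C)ccc1C(CC)(CC)c1ccc(OCCC(O)(CC)CC)c(C)c1`), compound 2 (`CCn1c(C(=O)N(CCC#N)CCC#N)ccc1C(CC)(CC)c1ccc(OCCC(O)(CC)CC)c(C)c1`) and compound 3 (`CCn1c(C(=O)N(C)CC(=O)O)ccc1C(CC)(CC)c1ccc(OCCC(O)(CC)CC)c(C)c1`). In an ADME assay on L02 cells (Homo sapiens) for antiproliferative activity, read by MTT assay, with a stated time of 48 h (on this read-out lower numbers stand for stronger inhibition and higher numbers for weaker inhibition), compound 1 gives 990 nM, compound 2 gives 37800 nM and compound 3 gives 2150 nM. Compound 3 therefore holds the middle place of the three numbers, far closer to compound 1 than to compound 2.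

Compound 4 (`CCn1c(C(=O)NC(CO)CCO)ccc1C(CC)(CC)c1ccc(OCCC(O)(CC)CC)c(C)c1`) has not yet been measured, and it changes the same place: a group of 7 heavy atoms (4 carbon, 1 nitrogen, 2 oxygen; no ring) in place of a group of 6 heavy atoms (3 carbon, 1 nitrogen, 2 oxygen; no ring), on a carbonyl carbon.

All three measured steps happened at this carbonyl carbon, so all of them bear on the change. One was modest, a 2.2-fold higher number from compound 1 to compound 3 (0.34 log units; beyond the scatter). Two were large, a 38-fold higher number from compound 1 to compound 2 (1.58 log units; beyond the scatter) and an 18-fold lower number from compound 2 to compound 3 (1.25 log units; beyond the scatter), and both involve compound 2. Changes here can thus matter a great deal, but no measured compound carries the group that enters, so the data cannot fix a direction. The entering group is only slightly larger than the one it replaces. The expected step in this assay is therefore a 1.3-fold higher number from compound 3 to compound 4 (0.11 log units; within the scatter), with no clear change beyond the scatter. For compound 4 the estimate is 2800 nM, with an expected range from 800 nM to 10000 nM.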

Compound 4, half-maximal inhibitory concentration: 3040 nM
Compound 4: the middle estimate sits 1.1-fold (0.04 log units) below what was measured; the range from low to high includes it.
By their numbers in this assay, from the lowest: compound 1; then compounds 3 and 4 (each within the scatter of the next); then compound 2.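

In this assay, replacing (carboxymethyl)(methyl)amino on the carbonyl carbon with the larger group of compound 4, which has 3 hydrogen-bond donors rather than 1, gives a 1.4-fold higher number from compound 3 to compound 4 (0.15 log units; within the scatter), so these two quite different groups cannot be told apart here. This shows that a large step is not a general feature of every exchange at this position: compound 4 stays far from compound 2, with a 12-fold lower number from compound 2 to compound 4 (1.09 log units; beyond the scatter), and now two compounds, rather than one, sit well apart from compound 2, while compound 1 keeps the lowest number, with a 3.1-fold higher number from compound 1 to compound 4 (0.49 log units; beyond the scatter), a modest step in which 3-hydroxy-1-(hydroxymethyl)propyl replaces 2-(dimethylamino)ethyl on the amide-type nitrogen. No supporting data explain why these groups give the numbers they do.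

With so few groups shown, it remains open whether the lower number of compound 1 depends on the amine at the end of its chain, which a simple hydroxyethyl chain or a longer chain ending in the same amine could test. Going by these compounds, it is also open whether the high number of compound 2 goes with its nitrile groups or with the two chains on one nitrogen, which a single nitrile-bearing chain could separate.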